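Ester to carbamate on the side chain of compound 1

The source may hold more compounds than are shown below. What is called first, only, known or untested is meant among the compounds shown, and "the series" means these compounds.

Compound 1 `CCCCCC(=O)OCC1CN(C(=O)c2cc(OC)c(OC)c(OC)c2)CCN1C(=O)c1cc(OC)c(OC)c(OC)c1` gives 290 nM in a functional assay (Oryctolagus cuniculus) for inhibition of platelet-activating factor receptor (Cavia porcellus) (on this read-out lower numbers stand for stronger inhibition and higher numbers for weaker inhibition), the only number shown for it. Compound 2 `CCC(CC)C(=O)OCC1CN(C(=O)c2cc(OC)c(OC)c(OC)c2)CCN1C(=O)c1cc(OC)c(OC)c(OC)c1` gives 70 nM; 40 nM; 60 nM (3 entries) in this assay, with repeated entries (the several entries of compound 2 in this assay, 70 nM; 40 nM; 60 nM (3 entries)). Compound 3 `COc1cc(C(=O)N2CCN(C(=O)c3cc(OC)c(OC)c(OC)c3)C(COC(=O)NCCC(C)C)C2)cc(OC)c1OC` has not yet been measured in this assay; it differs from compound 1 by isopentylamino in place of pentyl on a carbonyl carbon, on a carbonyl carbon whose other neighbour is oxygen next to a carbonyl group. Within the data shown here, no measured pair matches this change. A small move toward stronger inhibition, hardly beyond the scatter, is expected from compound 1 to compound 3 a 1.5-fold lower number from compound 1 to compound 3 (0.16 log units; within the scatter). Compound 3 is estimated at 200 nM, between 60 nM and 700 nM.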

Compound 3, half-maximal inhibitory concentration: 140 nM
Estimate against measurement, compound 3: 1.4-fold (0.15 log units) above; the measured number falls inside the stated range.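

On a carbonyl carbon whose other neighbour is oxygen next to a carbonyl group, isopentylamino can replace pentyl with inhibition retained: in this assay the change gives a 2.1-fold lower number from compound 1 to compound 3 (0.32 log units; beyond the scatter). The ester is therefore not required at this position, and the carbamate of compound 3 counts as a modest gain. Repeat entries indicate how far readings in this series can spread: the several entries of compound 2 in this assay, 70 nM; 40 nM; 60 nM (3 entries)

Among these compounds, the single step changes both the linking atom and the chain shape, so their shares remain unseparated. An unbranched pentylamino, a shorter alkylamino chain or a cyclohexylamino group would help divide them.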